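The source may report more compounds than this note shows. Statements on the series, on what has been measured and on what is new or still open speak of the compounds shown alone.

Measured compounds:
compound 1 `O[C@@H](CCc1ccccc1)C[C@@H](O)CCc1ccccc1` — 148 ug/mL
compound 2 `O[C@H](CCc1ccccc1)C[C@@H](O)CCc1ccccc1` — 164 ug/mL

Compound 1 gives 148 ug/mL in a functional assay on A-375 cells (Homo sapiens) for antiproliferative activity, read by MTT assay, with a stated time of 48 h (a lower number here means a stronger inhibitor, a higher number a weaker inhibitor), the lower of two numbers; compound 2 gives 164 ug/mL, and the step of a 1.1-fold higher number from compound 1 to compound 2 (0.04 log units; within the scatter) rests on (the fact that compounds 1 and 2 differ only in the configuration as drawn). Compound 3 `Oc1ccc(CC[C@H](O)C[C@@H](O)CCc2ccccc2)cc1` is not yet measured. It differs from compound 1 by hydroxy in place of hydrogen on an aromatic carbon. Within the data shown here, no measured step involves a change of this kind, and the single step known, a 1.1-fold higher number from compound 1 to compound 2 (0.04 log units; within the scatter), is a change of configuration alone, so no direction is indicated. He therefore expects no step beyond the scatter, a 1.1-fold lower number from compound 1 to compound 3 (0.02 log units; within the scatter). For compound 3 the estimate is 140 ug/mL, with a range of 60 ug/mL to 320 ug/mL.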

Compound 3, half-maximal inhibitory concentration: 56.3 ug/mL
Beside the measured number, compound 3's estimate is 2.5-fold (0.40 log units) above it; measured number below the stated range.
By their numbers in this assay, from the lowest: compound 3; then compounds 1 and 2 (each within the scatter of the next).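

In this assay, hydroxy in place of hydrogen on an aromatic carbon brings a 2.6-fold lower number from compound 1 to compound 3 (0.42 log units; beyond the scatter) as a modest step. The one earlier change, of configuration alone, stayed within the scatter, so this is the first sign that the number responds to a change among these compounds, here on the six-membered aromatic ring, para to a large group. Nothing available here accounts for the step. Going by these compounds, whether a methoxy group, an amine or a carboxylic acid in the same place would act like hydroxy remains open. So does whether hydroxy would bring a similar step on the configuration of compound 2.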